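Aryl urea series: moving the methoxy group on the aniline

This account rests on a few compounds, and the source may have more. Where it says the series, first, only, none or still open, it means among the compounds named here.

Measured so far in a functional assay on CRL2813 cells (Homo sapiens) for cytotoxicity, read by sulforhodamine B assay, with a stated time of 5 days; on this read-out lower numbers stand for stronger inhibition and higher numbers for weaker inhibition:
- compound 1 `O=C(Nc1cccc(C(F)(F)F)c1)N[C@H]1CC[C@H](Oc2ccc(C(F)(F)F)cc2)CC1`: 460 nM
- compound 2 `COc1cccc(NC(=O)N[C@H]2CC[C@H](Oc3ccc(F)cc3)CC2)c1`: 14000 nM
- compound 3 `O=C(Nc1cccc(C(F)(F)F)c1)N[C@H]1CC[C@H](Oc2ccccc2C(F)(F)F)CC1`: 1400 nM

Compound 2 stands at the highest number of the three, beyond the scatter from compound 3 and further still from compound 1; the numbers for compound 1 and compound 3 both sit well below it.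

Compound 4 `COc1ccc(NC(=O)N[C@H]2CC[C@H](Oc3ccc(F)cc3)CC2)cc1` is not yet measured. It differs from compound 2 only in the aniline part: 4-methoxyphenyl in place of 3-methoxyphenyl on an amide-type nitrogen. The group that leaves is 3-methoxyphenyl and the group that enters is 4-methoxyphenyl, on an amide-type nitrogen whose other neighbour is the carbonyl carbon.

For the measured compounds named here, the one measured step that resembles this is a 3.0-fold higher number from compound 1 to compound 3 (0.48 log units; beyond the scatter), a positional shift of a trifluoromethyl group, but on the aryl ether side rather than on the urea nitrogen, and it moved the number up when the substituent left the 4-position. Going by the values given here, no step on the aniline side has been measured, so the direction for compound 4 cannot be read from the data; a modest step of either sign, or none beyond the scatter, is plausible.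

The estimate for compound 4 in this assay is 12000 nM, with a range of 3500 nM to 40000 nM. This corresponds to an expected step of a 1.2-fold lower number from compound 2 to compound 4 (0.07 log units; within the scatter).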

Compound 4, half-maximal inhibitory concentration: > 20000 nM
Compound 4 was reported as a limit; the forecaster's own chance of this, stated with the estimate: 15%; middle value at least 1.6-fold (0.22 log units) from the limit.
By their numbers in this assay, from the lowest: compound 1; then compound 3; then compound 2. At a limit, above all of these: compound 4.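

Compound 4 is reported only as a limit, > 20000 nM, in this assay. For the compounds shown here, this gives the first reading on the aniline side of the series, an at least 1.4-fold higher number from compound 2 to compound 4 (0.15 log units; that floor lies within the scatter), so 4-methoxyphenyl in place of 3-methoxyphenyl on the amide-type nitrogen brings no drop in the number, although the floor of the step does not by itself establish a rise. On the aryl ether side, the step of a 3.0-fold higher number from compound 1 to compound 3 (0.48 log units; beyond the scatter) left the lower number with the 4-(trifluoromethyl)phenyl group, and no such advantage for the 4-substituted isomer appears in the methoxy pair, so that ether-side reading does not carry over to the aniline side.

From the compounds shown here alone, the true size of the methoxy shift stays open because the result for compound 4 is bounded only on one side: the limit of > 20000 nM in this assay, at which 1 of the 4 values shown sits. Also open, going by these compounds, is whether a nitrile, an amine or a carboxylic acid in place of methoxy on the aniline ring would bring the number down with the 4-fluorophenyl ether retained.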